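One methyl fewer on compound 2

The source may hold more compounds than are shown below. What is called first, only, known or untested is meant among the compounds shown, and "the series" means these compounds.

In a functional assay on thoracic aorta (Rattus norvegicus, strain Wistar), with a stated time of 15 min (on this read-out higher numbers stand for an effect only at larger amounts of compound and lower numbers for an effect already at smaller amounts), compound 2 (`Cc1ccc(S(=O)(=O)NC(=O)NC(C)c2ccccc2OCc2ccccc2)cc1`) reads > 200000 nM and this is a limit of the assay, not a number. Compound 4 (`CC(NC(=O)NS(=O)(=O)c1ccccc1)c1ccccc1OCc1ccccc1`) carries hydrogen in place of methyl on an aromatic carbon, para to a large group (hydrogen in place of methyl on an aromatic carbon), so that a 4-methylphenyl becomes a phenyl.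

Among the measured compounds shown here, compound 3 (`Cc1ccc(S(=O)(=O)NC(=O)NC(C)c2cc(C)ccc2OCc2ccccc2)cc1`) gives 91900 nM in this assay and offers the one measured step that bears on this change. There, an at least 2.1-fold lower number from compound 2 to compound 3 (0.33 log units; beyond the scatter) came with methyl in place of hydrogen on an aromatic carbon, though not at the carbon that changes here. Compound 1 (`CCOc1ccc(Cl)cc1C(C)NC(=O)N(C)S(=O)(=O)c1ccccc1`) gives 10500 nM in this assay but no single change links it to compound 4.

For the measured compounds named here, with an at least 2.1-fold lower number from compound 2 to compound 3 (0.33 log units; beyond the scatter) as the only guide, losing a methyl is expected to move the number modestly upward, if it moves it at all. The expected change is a step that the limit leaves unreadable from compound 2 to compound 4 and it is only a rough figure, given that the starting point is a limit. Compound 4 is estimated at 250000 nM with an expected range from 100000 nM to 600000 nM and it may well turn out to be only a limit too.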

Compound 4, half-maximal effective concentration: > 200000 nM
Compound 4: a limit, no number (the forecaster's own chance of this, stated with the estimate: 70%); the middle value does not contradict the limit.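

In this assay compound 4 gives > 200000 nM, which is a limit of the assay and not a number. Compound 2 also gives only a limit, so no step can be read for the change from 4-methylphenyl to phenyl between compound 2 and compound 4. Whether removing this methyl changes the effect at all stays open, with both compounds resting on the same limit: the limit of > 200000 nM in this assay, at which 2 of the 4 values shown sit.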